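The source may hold more compounds than are shown below. What is called first, only, known or untested is meant among the compounds shown, and "the series" means these compounds.

Measured compounds:
compound 1 `Cc1ccc(-n2nc(C(=O)Nc3ccc(Oc4ncnc5ccsc45)cc3)c(C)cc2=O)cc1` — 23800 nM
compound 2 `Cc1cc(=O)n(-c2ccc(Br)cc2F)nc1C(=O)Nc1ccc(Oc2ncnc3sccc23)cc1` — 15200 nM
compound 3 `Cc1cc(=O)n(-c2ccccc2OC(F)(F)F)nc1C(=O)Nc1ccc(Oc2ncnc3sccc23)cc1` — 11000 nM

In a functional assay on MCF7 cells (Homo sapiens) for cytotoxicity, read by MTT assay, with a stated time of 72 h (on this read-out higher numbers stand for weaker inhibition and lower numbers for stronger inhibition), compound 3 gives the lowest of the three numbers. Its nearest neighbour is compound 2, and the step of a 1.4-fold lower number from compound 2 to compound 3 (0.14 log units; within the scatter) lies within the scatter, so these two compounds cannot be told apart on this read-out. Compound 1 stands furthest from compound 3 and its number is beyond the scatter above it.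

Compound 4 `Cc1ccc(-n2nc(C(=O)Nc3ccc(Oc4ncnc5sccc45)cc3)c(C)cc2=O)cc1` has not yet been measured. It differs from compound 3 in one place: 4-methylphenyl in place of 2-(trifluoromethoxy)phenyl on an aromatic nitrogen. Going by the values given here, the only measured step at this position, from compound 2 to compound 3, was within the scatter, so swapping one aryl group for another on the aromatic nitrogen has so far moved the number little. Compound 1 also carries a 4-methylphenyl there, but its core differs from that of compound 4, and no step between compound 1 and compound 4 is shown; only the two values can be compared. On this basis compound 4 is expected to give 17000 nM, with a range from 8000 nM to 38000 nM. The estimated step of a 1.5-fold higher number from compound 3 to compound 4 (0.19 log units; within the scatter) is expected to be small, leaning toward a higher number in line with compound 1.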

Compound 4, half-maximal inhibitory concentration: > 40000 nM
Compound 4: only a limit was reported; the forecaster's own chance of this, stated with the estimate: 10%; at least 2.3-fold (0.37 log units) between middle value and limit.
By their numbers in this assay, from the lowest: compounds 3, 2 and 1 (each within the scatter of the next, the first and the last beyond it). At a limit, above all of these: compound 4.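

Compound 4 gives no number in this assay, only a limit: the limit of > 40000 nM in this assay, at which 1 of the 4 values shown sits. The aryl group on the aromatic nitrogen therefore matters more than the earlier pair suggested: the swap between the two halogen-bearing aryl groups gives a 1.4-fold lower number from compound 2 to compound 3 (0.14 log units; within the scatter) and stays within the scatter, whereas 4-methylphenyl gives an at least 3.6-fold higher number from compound 3 to compound 4 (0.56 log units; beyond the scatter) and an at least 2.6-fold higher number from compound 2 to compound 4 (0.42 log units; beyond the scatter) and both lie beyond it. The change of core gives an at least 1.6-fold higher number from compound 1 to compound 4 (0.22 log units; that floor lies within the scatter) and, as that floor lies within the scatter, this step cannot be read, so these values do not separate the two cores.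

From the compounds shown here alone, it remains open whether the loss of the halogen-bearing groups or the arrival of the methyl group accounts for the shift. Going by these compounds, it is also open how an aryl group carrying an amine, a carboxylic acid or a longer chain in place of that methyl group would read at this position.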